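The source may hold more compounds than are shown below. What is called first, only, known or untested is meant among the compounds shown, and "the series" means these compounds.

Compound 1 `O=C(C[C@]1(O)CC[C@@H](Cc2ccc(F)cc2)CC1)Nc1ccc2[nH]c(=O)oc2c1` gives 42.4% in an ADME assay on the whole organism (strain Sprague-Dawley) for pharmacokinetics, with Rattus norvegicus as the target, using cassette dosing, at a dose of 1 mg/kg by the oral route; a higher number here means that a larger share of the oral dose reaches the circulation, a lower number that a smaller share of the oral dose reaches the circulation. Compound 2 `COc1ccc(C[C@H]2CC[C@](O)(CC(=O)Nc3ccc4[nH]c(=O)oc4c3)CC2)cc1` differs from it by methoxy in place of fluoro on an aromatic carbon, and in this assay compound 2 gives 16%, a step of a number 26.4 percentage points lower from compound 1 to compound 2 (beyond the scatter). Compound 3 `O[C@]1(Cc2cc(-c3cn[nH]c3)on2)CC[C@H](Cc2ccc(F)cc2)CC1` is built on another core; the difference between the two cores is not broken down here. In this assay compound 3 gives 78%, the highest of the three numbers and beyond the scatter from both compound 1 and compound 2. Compound 4 `COc1ccc(C[C@H]2CC[C@](O)(Cc3cc(-c4cn[nH]c4)on3)CC2)cc1` is not yet measured; it stands to compound 3 as compound 2 stands to compound 1, namely by methoxy in place of fluoro on an aromatic carbon. The two changes read alike, in the groups that leave and enter and in the place where they sit. Going by the values given here, the only measured instance of this change is the step of a number 26.4 percentage points lower from compound 1 to compound 2 (beyond the scatter) on the core of compound 1. From the compounds shown here alone, whether the same size carries over onto the core of compound 3 is unknown, so the step from compound 3 to compound 4 is expected as a number 28 percentage points lower from compound 3 to compound 4 (beyond the scatter) because of a number 26.4 percentage points lower from compound 1 to compound 2 (beyond the scatter). Compound 4 is therefore estimated at 50%, with a span from 28% to 72% kept wide since the change has a single measured instance.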

Compound 4, oral bioavailability: 23.7%
The estimate for compound 4 lay 26.3 percentage points above the measured number; measured number below the stated range.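

In this assay, methoxy in place of fluoro gives a lower number on both cores, and on the core of compound 3 the step is a number 54.3 percentage points lower from compound 3 to compound 4 (beyond the scatter). The direction of the change carries over between these two cores, but its size does not: the same change on two cores in this assay, a number 26.4 percentage points lower (beyond the scatter) from compound 1 to compound 2 and a number 54.3 percentage points lower (beyond the scatter) from compound 3 to compound 4, 27.9 percentage points apart, beyond the scatter of two such steps A step measured on one core is therefore no reliable measure of its size on the other, although two cores are too few to show how the size varies across the series, and these steps do not show which part of the cores goes with the difference or why it arises.

From the compounds shown here alone, only fluoro and methoxy are compared in this place, so it remains open how chloro, hydroxy or an amine on the same aromatic carbon would read on either core. Going by these compounds, it also remains open whether a third core would give a step nearer to that of the core of compound 1 or to that of the core of compound 3.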